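Series notes: aryloxypropanone tetrazoles, lipophilicity

The source may hold more compounds than are shown below. What is called first, only, known or untested is meant among the compounds shown, and "the series" means these compounds.

Measured so far:
compound 1 `CC(Oc1ccc(Oc2ccc(F)cc2)cc1)C(=O)Cn1nnc(-c2ccccc2)n1` — 5.3
compound 2 `CCCCCCCCc1ccc(OC(C)C(=O)Cn2nnc(-c3ccc(C(=O)OC)cc3)n2)cc1` — > 8

Both were run in a physicochemical assay for lipophilicity, read by HPLC, tested at 5 mM; a lower number here means a more polar compound, a higher number a more lipophilic compound. For compound 2 the read-out is a limit of the assay, not a number, and it sits at the upper end of the range. (the limit of > 8 in this assay, at which 1 of the 2 values shown sits). Compound 1 gives a number, 5.3, and it shares with compound 3 the 4-fluorophenoxy group and the rest of the core.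

Compound 3 `COC(=O)c1ccc(-c2nnn(CC(=O)C(C)Oc3ccc(Oc4ccc(F)cc4)cc3)n2)cc1` is not yet measured in this assay. The change from compound 2 is 4-fluorophenoxy in place of octyl on an aromatic carbon; in words, 4-fluorophenoxy in place of octyl on an aromatic carbon. Among the compounds with values here, no measured pair of the series differs in exactly this way.

The step from compound 2 to compound 3 is expected to be a clear fall, well beyond the scatter, a number at least 2.50 log units lower from compound 2 to compound 3 (beyond the scatter), guided by compound 1 with its 5.3. Compound 3 is estimated at 5.5, within 4.8 to 6.3.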

Compound 3, partition coefficient: 5.4
The estimate for compound 3 lay 0.10 log units above the measured number; the range from low to high includes it.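

In this assay, compound 2 reads > 8, which is a limit of the assay and not a number. With 4-fluorophenoxy in place of octyl on an aromatic carbon, the series shows a number at least as far down as the step allows: a number at least 2.60 log units lower from compound 2 to compound 3 (beyond the scatter) is the result of the change, and since it starts from a limit, only its smallest size is known. With methoxycarbonyl in place of hydrogen on an aromatic carbon, the step is a number 0.10 log units higher from compound 1 to compound 3 (within the scatter), so this assay does not separate this pair.

From the compounds shown here alone, the true size of the octyl to 4-fluorophenoxy step remains open, and a shorter chain in place of octyl could bring it into the measurable range. Going by these compounds, whether a carboxylic acid or an amine in place of methoxycarbonyl would separate from compound 3 also remains open.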